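Two inactive analogues and a sulfanyl replacement

A few compounds are considered here, and "the series" means these few. Any claim that something is new, unique, unknown or untested is made for them only; others in the source may bear on it.

Measured so far in a functional assay on KB cells (Homo sapiens) for inhibition; on this read-out lower numbers stand for stronger inhibition and higher numbers for weaker inhibition:
compound 1, `Nc1nc2cc(Cl)c(Cl)cc2n1COCCO`: > 100000 nM
compound 2, `CNc1nc2c(Cl)cc(Cl)cc2n1COCCO`: > 100000 nM

Both values are limits of the assay rather than numbers. For compound 1 the value > 100000 nM in this assay is a limit. For compound 2 the value > 100000 nM in this assay is likewise a limit. Among the measured compounds shown here, both measured compounds share (the limit of > 100000 nM in this assay, at which 2 of the 2 values shown sit), so compound 2 cannot be placed relative to compound 1: the two are simply indistinguishable at the ceiling of the measurement, and no step between compounds differing in one place can be quantified from them.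

Compound 3, `OCCOCn1c(S)nc2c(Cl)cc(Cl)cc21`, differs from compound 2 by sulfanyl in place of methylamino on an aromatic carbon. For the measured compounds named here, no measured step covers this exchange. Because compound 2 sits at the limit of > 100000 nM in this assay, at which 2 of the 2 values shown sit, compound 3 is expected to remain at or near the same ceiling, with no step beyond the scatter in either direction. The expected step in this assay is a number no higher from compound 2 to compound 3 (the limit leaves the size open). For compound 3 the estimate in this assay is 100000 nM, within 20000 nM to 300000 nM, with a high chance that only a limit is again reported.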

Compound 3, half-maximal inhibitory concentration: > 100000 nM
Compound 3 gave a limit, no number (the forecaster's own chance of this, stated with the estimate: 85%); the middle value lies on the limit itself.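

In this assay compound 3 gives > 100000 nM, which is a limit and not a number. No step can be read from compound 2 to compound 3, sulfanyl in place of methylamino on an aromatic carbon, because both sit at the same ceiling: the limit of > 100000 nM in this assay, at which 3 of the 3 values shown sit.

The compounds shown leave open whether any change to the shared core yields measurable inhibition, and how these groups would rank.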